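Swapping the amide aryl group on a naphthylmethyl-piperidine amide

The compounds below may be only part of what the source reports. "The series", "measured", "known", "first", "only" and "open" are said of these compounds alone.

Of the compounds shown here, two built on the same core have been measured in an assay on isolated protein for binding affinity to melanin-concentrating hormone receptor 1 (Homo sapiens); on this read-out higher numbers stand for weaker inhibition and lower numbers for stronger inhibition. Compound 1 `COc1ccc(C(=O)NC2CCN(Cc3ccc4ccccc4c3)CC2)cc1OC` gives 1000 nM. Among the compounds with values here, compound 2 `O=C(NC1CCN(Cc2ccc3ccccc3c2)CC1)c1ccc(Cl)cc1` gives 232 nM, the lowest of the two numbers, and the only measured step, a 4.3-fold lower number from compound 1 to compound 2 (0.63 log units; beyond the scatter), shows a modest gain on exchanging the aryl group on the carbonyl carbon. Compound 3 `CN(C)c1cccc(C(=O)NC2CCN(Cc3ccc4ccccc4c3)CC2)c1` differs from compound 2 only at that same position: 3-(dimethylamino)phenyl in place of 4-chlorophenyl on a carbonyl carbon. Within the data shown here, no measured step covers this particular exchange, so the single step from compound 1 to compound 2 is the only guide, and it only indicates that this assay is sensitive to what sits on the carbonyl carbon. Since the incoming group brings a hydrogen-bond acceptor, somewhat as compound 1 does, a modest move toward a weaker number seems plausible. Compound 3 is therefore expected to give about 500 nM, within a range from 150 nM to 1600 nM. That expectation amounts to a step of a 2.2-fold higher number from compound 2 to compound 3 (0.33 log units; beyond the scatter).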

Compound 3, inhibition constant: 125 nM
Beside the measured number, compound 3's estimate is 4.0-fold (0.60 log units) above it; the whole stated range lies above it.
By their numbers in this assay, from the lowest: compounds 3 and 2 (each within the scatter of the next); then compound 1.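

In this assay, exchanging 4-chlorophenyl for 3-(dimethylamino)phenyl on the carbonyl carbon gives a 1.9-fold lower number from compound 2 to compound 3 (0.27 log units; within the scatter) and so does not separate the two groups, although only the entering group carries a hydrogen-bond acceptor. Set against the 3,4-dimethoxyphenyl group, the same entering group gives an 8.0-fold lower number from compound 1 to compound 3 (0.90 log units; beyond the scatter) and this shows that the gap from compound 1 does not depend on having chlorine in the aryl group, since compound 2 and compound 3 both stand clear of compound 1 by more than the scatter. No measurement is available that explains these results.

From the compounds shown here alone, how an unsubstituted phenyl or a pyridine ring would read on the carbonyl carbon remains open. So does whether 3-chlorophenyl or 4-(dimethylamino)phenyl would match the two groups seen here.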